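Working notes: from compound 1 to compound 4

The source may hold more compounds than are shown below. What is called first, only, known or untested is meant among the compounds shown, and "the series" means these compounds.

Values measured in a functional assay on ZR-75-1 cells (Homo sapiens) for inhibition, read by sulforhodamine B assay (a higher number here means a weaker inhibitor of growth, a lower number a stronger inhibitor of growth), so far:
- compound 1 `Cc1ccc2[nH]c(-c3ccc(-c4ccc(-c5cccc(Cl)c5)cc4)cc3)nc2c1` gives 3450 nM
- compound 2 `COc1ccc(-c2ccc(-c3ccc(-c4nc5ccccc5[nH]4)cc3)cc2)cc1` gives 35100 nM
- compound 3 `Clc1cccc(-c2ccc(-c3ccc(-c4nc5ccccc5[nH]4)cc3)cc2)c1` gives 41200 nM

Of these three, compound 1 has the lowest number, at 3450 nM in this assay and clearly apart from the other two. The change under review leads to compound 4 `Cc1ccc2[nH]c(-c3ccc(-c4ccc(-c5ccc(C(F)(F)F)cc5)cc4)cc3)nc2c1` and is 4-(trifluoromethyl)phenyl in place of 3-chlorophenyl on an aromatic carbon, with 4-(trifluoromethyl)phenyl in place of 3-chlorophenyl on an aromatic carbon, para to a large group. For the measured compounds named here, no measured compound carries the incoming group. The nearest evidence is the exchange of 4-methoxyphenyl for 3-chlorophenyl, a 1.2-fold higher number from compound 2 to compound 3 (0.07 log units; within the scatter), which stayed within the scatter, although compounds 2 and 3 both lack the methyl group. The step of hydrogen in place of methyl, a 12-fold higher number from compound 1 to compound 3 (1.08 log units; beyond the scatter), was large, but compound 4 keeps that methyl, so this step does not transfer. The step expected in this assay is therefore small, a 1.1-fold higher number from compound 1 to compound 4 (0.04 log units; within the scatter), with none expected beyond the scatter and no firm direction. For compound 4 the estimate is 3800 nM, with an expected range from 1300 nM to 11000 nM in this assay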

Compound 4, concentration for 50% growth inhibition: 2410 nM
Estimate against measurement, compound 4: 1.6-fold (0.20 log units) above, and the stated range covers the measured number.
By their numbers in this assay, from the lowest: compounds 4 and 1 (each within the scatter of the next); then compounds 2 and 3 (each within the scatter of the next).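

In this assay, with the methyl group kept, the change gives a 1.4-fold lower number from compound 1 to compound 4 (0.16 log units; within the scatter), so this place on an aromatic carbon accepts 4-(trifluoromethyl)phenyl, with 10 heavy atoms, in place of 3-chlorophenyl, with 7, without a shift beyond the scatter. The earlier exchange at this place, a 1.2-fold higher number from compound 2 to compound 3 (0.07 log units; within the scatter), was read only in compounds lacking the methyl group; the new step shows a similarly small outcome, for a different pair of groups, in a compound that carries it. Nothing measured here gives a reason for this result.

On these data alone, whether an amine or a carboxylic acid on this phenyl ring would leave the number equally unchanged stays open. As far as these compounds go, the methyl step has been read only with 3-chlorophenyl, so its size with 4-(trifluoromethyl)phenyl also stays open.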